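Methanesulfonamide in Place of Carbamate: What Compound 4 Might Give

The source may hold more compounds than are shown below. What is called first, only, known or untested is meant among the compounds shown, and "the series" means these compounds.

Measured so far:
compound 1, `COC(=O)NCC1Cc2ccc(NC(=O)c3cccc(C)c3-c3ccc(C(F)(F)F)cc3)cc2C1`: 4.1 nM
compound 2, `COC(=O)NCC1Cc2ccc(NC(=O)c3cc(C)cc(C)c3-c3ccc(C(F)(F)F)cc3)cc2C1`: 2.2 nM
compound 3, `COC(=O)NCC1Cc2ccc(NC(=O)c3cccc(C)c3-c3ccc(Cl)cc3)cc2C1`: 8.7 nM

Compound 1 is the starting point. In an assay for inhibition of apolipoprotein B-100 (Homo sapiens), tested at 100 nM (a lower number here means a stronger inhibitor, a higher number a weaker inhibitor), compound 1 gives 4.1 nM, the second highest of the three numbers in hand. The nearest neighbour is compound 2, which gives 2.2 nM after the step of a 1.9-fold lower number from compound 1 to compound 2 (0.27 log units; within the scatter), so the two cannot be told apart. The furthest is compound 3, which gives 8.7 nM after the step of a 2.1-fold higher number from compound 1 to compound 3 (0.33 log units; beyond the scatter).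

Compound 4, `Cc1cccc(C(=O)Nc2ccc3c(c2)CC(CNS(C)(=O)=O)C3)c1-c1ccc(C(F)(F)F)cc1`, changes a different part of the molecule: methylsulfonyl in place of methoxycarbonyl on an amine nitrogen. Both measured steps concern groups on aromatic carbons of the shared core, and neither touches the amine nitrogen or its substituent. Going by the values given here, no step on that nitrogen has been measured, so the two measured steps give only a sense of scale: both were small, one within the scatter and one modest. On that basis the exchange of methoxycarbonyl for methylsulfonyl is expected to produce a small step in this assay, possibly none beyond the scatter, with no firm direction.

Compound 4 is therefore estimated at 6 nM, with a likely range from 2 nM to 20 nM. The step this estimate implies is a 1.5-fold higher number from compound 1 to compound 4 (0.17 log units; within the scatter), which is expected to stay close to the scatter.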

Compound 4, half-maximal inhibitory concentration: 6.5 nM
Beside the measured number, compound 4's estimate is 1.1-fold (0.03 log units) below it; measured number inside the range.
By their numbers in this assay, from the lowest: compounds 2, 1, 4 and 3 (each within the scatter of the next, the first and the last beyond it).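

In this assay, methylsulfonyl in place of methoxycarbonyl on the amine nitrogen gives a 1.6-fold higher number from compound 1 to compound 4 (0.20 log units; within the scatter), the first step measured at this position, and it cannot be told apart from no change. The earlier steps shown here concerned only groups on aromatic carbons of the shared core, whereas this one shows that the (methoxycarbonyl)amino group can give way to a methanesulfonamido group, with the same count of heavy atoms and hydrogen-bond acceptors, while the number stays within the scatter of the starting compound. Nothing among the data given accounts for this result, so the tolerance of this position is recorded here as an observation only.

One exchange on one nitrogen leaves open whether an acetyl group, a longer chain such as ethylsulfonyl, or the free amine would stay equally close to compound 1 in this assay. As far as these compounds go, it also remains open whether methylsulfonyl on this nitrogen would give a step of similar size on the cores of compound 2 and compound 3, which carry the extra methyl and the chloro group.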